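The source may hold more compounds than are shown below. What is called first, only, known or untested is meant among the compounds shown, and "the series" means these compounds.

Going by the values given here, in an ADME assay on GES1 cells (Homo sapiens) for inhibition, read by MTT assay, with a stated time of 72 h (a lower number here means a stronger inhibitor, a higher number a weaker inhibitor), compound 1 `Cc1cc(Nc2cc(-c3ccccc3)[nH]n2)n2nc(SCCc3ccccc3)nc2n1` gives 37400 nM and compound 2 `Cc1ccc(CSc2nc3nc(C)cc(Nc4cc(-c5ccccc5)[nH]n4)n3n2)cc1` gives 36200 nM, so compound 2 stands level with the only other measured compound. Compound 3 `CCCSc1nc2nc(C)cc(Nc3cc(-c4ccccc4)[nH]n3)n2n1` keeps the shared core and changes the group on the sulfur: ethyl in place of 4-methylphenyl on a saturated chain carbon bound to a sulfur. In words, this is ethyl in place of 4-methylphenyl on a saturated chain carbon bound to a sulfur. Among the compounds with values here, one measured step bears on this place: a 1.0-fold lower number from compound 1 to compound 2 (0.01 log units; within the scatter), which stays within the scatter. Both measured compounds keep an aromatic ring there, so the data do not show what losing it does. On the evidence of that flat step, no shift beyond the scatter is expected in this assay, and no direction can be given. The expected change is a 1.1-fold higher number from compound 2 to compound 3 (0.04 log units; within the scatter). The estimated value for compound 3 is 40000 nM, with an expected range of 18000 nM to 90000 nM.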

Compound 3, half-maximal inhibitory concentration: > 50000 nM
Compound 3: no number, only a limit (the forecaster's own chance of this, stated with the estimate: 15%); middle value at least 1.2-fold (0.09 log units) away from the limit.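

Compound 3 is the only compound shown that carries no aromatic ring on the sulfur side chain, and its reading is a limit of the assay, not a number: the limit of > 50000 nM in this assay, at which 1 of the 3 values shown sits. In this assay, the loss of that ring gives an at least 1.3-fold higher number from compound 2 to compound 3 (0.14 log units; that floor lies within the scatter), and the matching change from the longer side chain gives an at least 1.3-fold higher number from compound 1 to compound 3 (0.12 log units; that floor lies within the scatter). Both floors lie within the scatter, so the position may be more sensitive to losing the ring than the flat step between the two ring-bearing compounds suggested, but this result does not establish it.

From the compounds shown here alone, how far the true value of compound 3 lies past the limit stays open. So does whether a longer chain such as butyl, or an amine at the end of the chain, would give a readable number in this assay.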